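The source may hold more compounds than are shown below. What is called first, only, known or untested is meant among the compounds shown, and "the series" means these compounds.

Compound 1 `CN1CCN(C(=O)/C=C/c2ccncc2-c2ccc3ccccc3c2)CC1` is the starting point, and in a functional assay on HCT-116 cells (Homo sapiens) for inhibition, read by MTT assay, with a stated time of 72 h (a higher number here means a weaker inhibitor of growth, a lower number a stronger inhibitor of growth), compound 1 gives > 30000 nM, a result that is a limit of the assay rather than a number. That puts compound 1 at the limit of > 30000 nM in this assay, at which 1 of the 3 values shown sits, the weakest end of what this assay can report. Two other compounds share the core of compound 1 with different substituents. Within the data shown here, compound 2 `CCOC(=O)/C=C/c1ccncc1-c1ccc2cc[nH]c2c1` is the only one with a single number: in this assay compound 2 gives 2140 nM. Compound 3 `Cn1ccc2cc(-c3cnccc3/C=C/C(=O)N3CCOCC3)ccc21` has no result reported in this assay, where compound 3 gives "not determined" (no result reported). The step to be followed leads to compound 4 `NC(=O)/C=C/c1ccncc1-c1ccc2ccccc2c1`, which differs from compound 1 by amino in place of 4-methylpiperazin-1-yl on a carbonyl carbon. Among the measured compounds shown here, no step between two measured compounds is available, so the direction and size of the change expected from compound 1 to compound 4 are estimated with caution: it is expected that an at least 5.0-fold lower number from compound 1 to compound 4 (0.69 log units; beyond the scatter) moves toward stronger growth inhibition, though the starting limit leaves its size open. Compound 4 is estimated to give about 6000 nM, within a range from 800 nM to 30000 nM.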

Compound 4, concentration for 50% growth inhibition: 12100 nM
Estimate against measurement, compound 4: 2.0-fold (0.30 log units) below; low and high end bracket the measured number.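

In this assay, amino in place of 4-methylpiperazin-1-yl on a carbonyl carbon gives an at least 2.4-fold lower number from compound 1 to compound 4 (0.39 log units; beyond the scatter). This shows that, on the core of compound 1, the six-membered ring of the amide is not required for a number to be read at this position, since the bare carbamoyl group of compound 4 yields one. The true size of the step stays open because compound 1 stands at a limit of the assay: the limit of > 30000 nM in this assay, at which 1 of the 4 values shown sits.

From the compounds shown here alone, what remains open is whether a small substituted amide such as a methylamino group, or a carboxylic acid, on the same carbonyl carbon would move the number further. Compound 2 differs from compound 4 in more than one place, so the compounds shown do not separate the effect of the carbonyl substituent from that of the other changes.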